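The source may hold more compounds than are shown below. What is called first, only, known or untested is meant among the compounds shown, and "the series" means these compounds.

Compound 1 `Cc1ccc2c(=O)c(CSC(=S)N(C(C)C)C(C)C)coc2c1` gives 240 nM in a functional assay on MDA-MB-435S cells (Homo sapiens) for antiproliferative activity, read by MTT assay, with a stated time of 72 h; a higher number here means a weaker inhibitor, a lower number a stronger inhibitor. Compound 2 `CC(C)N(C(=S)SCc1coc2ccccc2c1=O)C(C)C` gives 7900 nM in this assay.

Going by the values given here, compound 2 has the higher of the two numbers so far, and the only measured neighbour is compound 1, where the step of a 33-fold higher number from compound 1 to compound 2 (1.52 log units; beyond the scatter) came with a 33-fold higher number from compound 1 to compound 2 (1.52 log units; beyond the scatter) being described as the loss of a methyl on an aromatic carbon of the shared core. Compound 3 `CC(C)N(C(=S)SCc1coc2cc(Cl)ccc2c1=O)C(C)C` differs from compound 2 by chloro in place of hydrogen on an aromatic carbon. Among the compounds with values here, no measured step covers a chloro group, so the methyl step is the only comparison at hand, and it shows that a small group on that ring can move the number a great deal. It is therefore expected that adding chloro brings the number down from compound 2, though by less than the methyl step, giving the estimated step of a 5.3-fold lower number from compound 2 to compound 3 (0.72 log units; beyond the scatter). Compound 3 is estimated at 1500 nM, with a range from 300 nM to 6000 nM.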

Compound 3, half-maximal inhibitory concentration: > 25000 nM
Compound 3 gave a limit, no number; the forecaster's own chance of this, stated with the estimate: 5%; at least 16-fold (1.22 log units) between middle value and limit.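

This position responds in both directions: methyl gives compound 1 the lowest number of the three, whereas chloro in place of hydrogen gives an at least 3.1-fold higher number from compound 2 to compound 3 (0.50 log units; beyond the scatter). Comparing the two groups directly gives an at least 100-fold higher number from compound 1 to compound 3 (2.01 log units; beyond the scatter), so in this small set the outcome depends on which group sits on this carbon, not merely on whether a hydrogen has been replaced. Compound 3 stands at a limit and not at a number, so both steps give only a minimum size: the limit of > 25000 nM in this assay, at which 1 of the 3 values shown sits.

The compounds shown leave open how other groups on this carbon would behave, such as fluoro, methoxy, an amine or a longer chain like ethyl. They also leave open whether methyl and chloro would differ in the same way on the other carbons of this ring.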